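A few compounds are considered here, and "the series" means these few. Any claim that something is new, unique, unknown or untested is made for them only; others in the source may bear on it.

Compound 1 `CC#CC(CC(=O)O)c1ccc(OCc2ccc3nc(-c4ccc(CC)cc4)cn3c2)cc1` is one of three compounds that share a core and differ in the group on the terminal phenyl ring. In an assay on isolated protein for agonist activity at Free fatty acid receptor 1 (Homo sapiens) (on this read-out higher numbers stand for an effect only at larger amounts of compound and lower numbers for an effect already at smaller amounts), compound 1 gives 496 nM. Compound 3 `CC#CC(CC(=O)O)c1ccc(OCc2ccn3cc(-c4ccc(C(F)(F)F)cc4)nc3c2)cc1` gives 674 nM, a number within the scatter of compound 1, while compound 2 `CC#CC(CC(=O)O)c1ccc(OCc2ccn3cc(-c4cccc(C)c4)nc3c2)cc1` gives 1510 nM, a higher number beyond it. Among the measured compounds shown here, the only single-point step measured, a 2.2-fold lower number from compound 2 to compound 3 (0.35 log units; beyond the scatter), was modest. Compound 4 `CC#CC(CC(=O)O)c1ccc(OCc2ccc3nc(-c4ccc(C5CCCCC5)cc4)cn3c2)cc1` arises from compound 1 by cyclohexyl in place of ethyl on an aromatic carbon. For the measured compounds named here, no measured step exchanges ethyl for cyclohexyl, so only the modest size of the one step on this phenyl ring guides expectation. Compound 4 is therefore expected to stay near compound 1, with a step of a 1.2-fold lower number from compound 1 to compound 4 (0.09 log units; within the scatter) in this assay, giving an estimate of 400 nM with a range from 130 nM to 1300 nM.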

Compound 4, half-maximal effective concentration: 417 nM
Compound 4: the middle estimate sits 1.0-fold (0.02 log units) below what was measured; the measured number falls inside the stated range.
By their numbers in this assay, from the lowest: compounds 4, 1 and 3 (each within the scatter of the next); then compound 2.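

At this position on the terminal phenyl ring, ethyl, with 2 heavy atoms and no ring, gives way to cyclohexyl, with 6 heavy atoms and a six-membered non-aromatic ring, and this assay shows a 1.2-fold lower number from compound 1 to compound 4 (0.08 log units; within the scatter), so this much larger carbon-only group leaves the number where it was. Nothing measured on these compounds speaks to the cause of this result.

On these data alone, whether the same position on the core of compound 1 also tolerates an amine or a carboxylic acid remains open.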